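The compounds below may be only part of what the source reports. "The series", "measured", "known", "first", "only" and "open" are said of these compounds alone.

Measured so far in this assay:
compound 1 `CC(C)=CC(=O)Nc1c(C(O)(C(F)(F)F)C(F)(F)F)ccc2ccccc12`: 46 nM
compound 2 `COCC(=O)Nc1c(C(O)(C(F)(F)F)C(F)(F)F)ccc2ccccc12`: 213 nM
compound 3 `O=C(Nc1c(C(O)(C(F)(F)F)C(F)(F)F)ccc2ccccc12)c1cccc(Br)c1`: 80 nM

In an assay on LtK cells with ATP-sensitive inward rectifier potassium channel 11 (Homo sapiens) as the target (on this read-out higher numbers stand for an effect only at larger amounts of compound and lower numbers for an effect already at smaller amounts), compound 3 gives the second highest of the three numbers. Its nearest neighbour is compound 1, with a 1.7-fold higher number from compound 1 to compound 3 (0.24 log units; within the scatter); its furthest is compound 2, with a 2.7-fold lower number from compound 2 to compound 3 (0.43 log units; beyond the scatter). Compound 4 `O=C(Nc1c(C(O)(C(F)(F)F)C(F)(F)F)ccc2ccccc12)c1ccc(Cl)c(Cl)c1` differs from compound 3 only in the group on the carbonyl carbon: 3,4-dichlorophenyl in place of 3-bromophenyl on a carbonyl carbon. Both measured steps exchange the whole group on that carbonyl carbon for one of a different kind, and neither swaps one aromatic ring for another, so they bear on the new step only loosely; the aromatic case of compound 3 sits close to compound 1. No step beyond the scatter is therefore expected, a 1.1-fold lower number from compound 3 to compound 4 (0.06 log units; within the scatter). Compound 4 is estimated at 70 nM, within 30 nM to 170 nM.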

Compound 4, half-maximal effective concentration: 194 nM
Estimate against measurement, compound 4: 2.8-fold (0.44 log units) below, outside the stated range (above it).
By their numbers in this assay, from the lowest: compounds 1 and 3 (each within the scatter of the next); then compounds 4 and 2 (each within the scatter of the next).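

On the carbonyl carbon, exchanging one substituted phenyl group for another is not neutral: 3,4-dichlorophenyl in place of 3-bromophenyl moves the number beyond the scatter (a 2.4-fold higher number from compound 3 to compound 4 (0.38 log units; beyond the scatter)). Compound 4 stays within the scatter of the methoxymethyl amide (a 1.1-fold lower number from compound 2 to compound 4 (0.04 log units; within the scatter)) but remains apart from the 2-methylprop-1-en-1-yl amide (a 4.2-fold higher number from compound 1 to compound 4 (0.63 log units; beyond the scatter)). No supporting data explain this step.

The compounds shown do not separate the change of halogen from the added chlorine, which a 3-chlorophenyl group would address. From the compounds shown here alone, how a phenyl ring carrying an amine or a carboxylic acid behaves at this place also remains open.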